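Compound 3: a new aryl group on the shared core

The source may report more compounds than this note shows. Statements on the series, on what has been measured and on what is new or still open speak of the compounds shown alone.

Compound 1 `COc1ccc(-c2nc3c(-c4cc(OC)c(OC)c(OC)c4)cccc3o2)cc1OC` and compound 2 `COc1cc(OC)cc(-c2nc3c(-c4cc(OC)c(OC)c(OC)c4)cccc3o2)c1` share one core and differ in the placing of their dimethoxyphenyl groups. In a functional assay on MCF7 cells (Homo sapiens) for antiproliferative activity, read by MTT assay, with a stated time of 48 h (a lower number here means a stronger inhibitor, a higher number a weaker inhibitor), compound 1 gives > 25000 nM, which is a limit of the assay. Compound 2 gives > 25000 nM, also a limit and not a number. Compound 2 therefore has no measured position, and the one other figure beside it is a limit too: the limit of > 25000 nM in this assay, at which 2 of the 2 values shown sit. Within the data shown here, the only measured step is a step that the two limits leave unreadable from compound 1 to compound 2, so it offers no size to carry forward.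

Compound 3 `COc1ccc(-c2nc3c(-c4cc(OC)c(OC)c(OC)c4)cccc3o2)cc1F` keeps the core and places 3-fluoro-4-methoxyphenyl in place of 3,5-dimethoxyphenyl on the same aromatic carbon of the five-membered aromatic ring: 3-fluoro-4-methoxyphenyl in place of 3,5-dimethoxyphenyl on an aromatic carbon. With no readable step behind it, no direction can be argued for this change, and the expectation stays anchored on compound 2 at > 25000 nM. In this assay the expected step is a number no higher from compound 2 to compound 3 (the limit leaves the size open), and a report of only a limit is the likeliest outcome. For compound 3 the estimated value is 25000 nM, with an expected range from 9000 nM to 60000 nM.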

Compound 3, half-maximal inhibitory concentration: > 25000 nM
Compound 3 was reported as a limit (the forecaster's own chance of this, stated with the estimate: 70%); the middle value sits exactly at the limit.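

In this assay compound 3 gives > 25000 nM, a limit and not a number. No step among compound 1, compound 2 and compound 3 can therefore be read: the limit of > 25000 nM in this assay, at which 3 of the 3 values shown sit.

The compounds shown leave open whether any aryl group at this place on the shared core gives a readable value in this assay.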